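Chain extension on the acid arm of the alkyne series

The source may hold more compounds than are shown below. What is called first, only, known or untested is meant among the compounds shown, and "the series" means these compounds.

Three compounds have numbers in a physicochemical assay for permeability, using PAMPA, with a stated time of 4 h, at pH 7.4, tested at 50 uM; on this read-out lower numbers stand for lower permeability and higher numbers for higher permeability. Compound 1 `Cc1c(F)cccc1CCCCOc1ccc(C#Cc2cccc3c(CCCC(=O)O)c(C)n(CCCC(=O)O)c23)cc1` gives 12.4 10^-6 cm/s, compound 2 `Cc1c(Cl)cccc1CCCCOc1ccc(C#Cc2cccc3c(CCC(=O)O)c(C)n(CCCCC(=O)O)c23)cc1` gives 4.6 10^-6 cm/s, and compound 3 `Cc1c(F)cccc1CCCCOc1ccc(/C=C/c2cccc3c(CCCC(=O)O)c(C)n(CC(=O)O)c23)cc1` gives 1.5 10^-6 cm/s. Compound 2 stands second highest of the three, below compound 1 and above compound 3, each of those gaps beyond the scatter. Compound 4 `Cc1c(Cl)cccc1CCCCOc1ccc(C#Cc2cccc3c(CCCC(=O)O)c(C)n(CCCCC(=O)O)c23)cc1` is not yet measured; it differs from compound 2 only by carboxymethyl in place of carboxy on a saturated chain carbon, two bonds along the chain from an aromatic carbon. Within the data shown here, no measured pair isolates this change, so no step is known for it. For compound 4 a modest rise from compound 2 is expected, a step from compound 2 to compound 4 of a 1.5-fold higher number from compound 2 to compound 4 (0.18 log units; within the scatter) in this assay, likely near the edge of the scatter. The estimate for compound 4 is 7 10^-6 cm/s, with a range from 3 10^-6 cm/s to 15 10^-6 cm/s.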

Compound 4, apparent permeability: 5 10^-6 cm/s
Compound 4: the middle estimate sits 1.4-fold (0.15 log units) above what was measured, and the stated range covers the measured number.
By their numbers in this assay, from the lowest: compound 3; then compounds 2 and 4 (each within the scatter of the next); then compound 1.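

In this assay, among these compounds, the one pair that isolates this change gives a 1.1-fold higher number from compound 2 to compound 4 (0.04 log units; within the scatter), so carboxymethyl in place of carboxy at this place, on a saturated chain carbon, two bonds along the chain from an aromatic carbon, does not separate the two compounds. The earlier compounds shown here each differed in more than one place and could not show this. Nothing available explains the result.

Open, going by these compounds, is whether a longer chain ending in a carboxylic acid, or a primary amide in place of the acid, would also stay within the scatter here. Also open, on these data alone, is whether this step holds with fluorine in place of chlorine on the shared core.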